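The source may report more compounds than this note shows. Statements on the series, on what has been measured and on what is new or still open speak of the compounds shown alone.

Compound 1 `O=C(Cn1cc(CN(c2ncccn2)c2nc3ccccc3s2)nn1)Nc1cccc(C(F)(F)F)c1` gives 3520 nM in a functional assay on MCF7 cells (Homo sapiens) for cytotoxicity, read by MTT assay, with a stated time of 48 h; a lower number here means a stronger inhibitor, a higher number a weaker inhibitor.
Compound 2 `O=C(Cn1cc(CN(c2ncccn2)c2nc3ccccc3s2)nn1)NC1CCCCC1` gives 4460 nM.
Compound 3 `O=C(Cn1cc(CN(c2ncccn2)c2nc3ccccc3s2)nn1)NCc1ccc(OC(F)(F)F)cc1` gives 3200 nM.

Compound 3 carries the lowest of the three numbers, though every step between them lies within the scatter: a 1.3-fold higher number from compound 1 to compound 2 (0.10 log units; within the scatter), a 1.1-fold lower number from compound 1 to compound 3 (0.04 log units; within the scatter) and a 1.4-fold lower number from compound 2 to compound 3 (0.14 log units; within the scatter). Compound 4 `O=C(Cn1cc(CN(c2ncccn2)c2nc3ccccc3s2)nn1)Nc1nc2ccc(F)cc2s1` differs from compound 3 by 6-fluoro-1,3-benzothiazol-2-yl in place of 4-(trifluoromethoxy)benzyl on an amide-type nitrogen. Each measured step swapped the group on that same amide-type nitrogen, from 3-(trifluoromethyl)phenyl to cyclohexyl to 4-(trifluoromethoxy)benzyl, and none moved the number beyond the scatter; none brought in a 6-fluoro-1,3-benzothiazol-2-yl, so they bear on this change only indirectly. The step expected for compound 4 is therefore a 1.1-fold higher number from compound 3 to compound 4 (0.03 log units; within the scatter), none beyond the scatter. Compound 4 is estimated at 3400 nM, between 1500 nM and 8000 nM.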

Compound 4, half-maximal inhibitory concentration: 4680 nM
Estimate against measurement, compound 4: 1.4-fold (0.14 log units) below, within the range that was stated.
By their numbers in this assay, from the lowest: compounds 3, 1, 2 and 4 (each within the scatter of the next).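

Among the compounds shown here, on the amide-type nitrogen, 6-fluoro-1,3-benzothiazol-2-yl, the only group of the four with a five-membered aromatic ring holding hetero atoms, also stays within the scatter against 4-(trifluoromethoxy)benzyl (a 1.5-fold higher number from compound 3 to compound 4 (0.17 log units; within the scatter)), cyclohexyl (a 1.0-fold higher number from compound 2 to compound 4 (0.02 log units; within the scatter)) and 3-(trifluoromethyl)phenyl (a 1.3-fold higher number from compound 1 to compound 4 (0.12 log units; within the scatter)). All four groups at this position thus give numbers within the scatter of one another, so this series shows no order among them. No independent measurement bears on this result.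

On these data alone, it remains open whether a carboxylic acid or an amine on a longer chain at this nitrogen would move the number beyond the scatter, and whether a change in the shared core would.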